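The source may hold more compounds than are shown below. What is called first, only, known or untested is meant among the compounds shown, and "the series" means these compounds.

Working notes on the piperazine-bearing series sharing the core seen in compound 1 `Nc1scc(CN2CCN(c3ccccc3C(F)(F)F)CC2)c1C(=O)c1ccc(Cl)cc1`. In a functional assay on CHO cells with adenosine receptor A1 (Homo sapiens) as the target, read by cAMP accumulation and immunoassay, with a stated time of 6 min, tested at 10 uM (a higher number here means a weaker effect of the compound at the concentration tested, a lower number a stronger effect), compound 1 gives -60%. Compound 2 `Nc1scc(CN2CCN(c3ccncc3)CC2)c1C(=O)c1ccc(Cl)cc1` gives -15% in this assay, and compound 3 `Nc1scc(CN2CCN(c3ccc(F)c(Cl)c3)CC2)c1C(=O)c1ccc(Cl)cc1` gives -78%. Among the three numbers compound 3 stands lowest, with compound 1 nearest and compound 2 furthest away. The measured steps are all exchanges of one aromatic group on the amine nitrogen in a ring for another: a number 45 percentage points higher from compound 1 to compound 2 (beyond the scatter); a number 18 percentage points lower from compound 1 to compound 3 (beyond the scatter); a number 63 percentage points lower from compound 2 to compound 3 (beyond the scatter). Each of them moved the number beyond the scatter, two of them by large amounts, so this position is sensitive.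

The next compound is compound 4 `Nc1scc(CN2CCN(CCCc3ccc(Cl)cc3)CC2)c1C(=O)c1ccc(Cl)cc1`. It differs from compound 3 as follows: 3-(4-chlorophenyl)propyl in place of 3-chloro-4-fluorophenyl on an amine nitrogen in a ring. Among the measured compounds shown here, no measured step covers an aromatic ring held away from the ring nitrogen by a three-carbon chain; the steps so far only exchange rings attached directly. They show that changes here can be large in either direction, and the 4-chlorophenyl entering carries no fluorine. The expectation is therefore a step toward a higher number, estimated as a number 33 percentage points higher from compound 3 to compound 4 (beyond the scatter), with wide uncertainty. For compound 4 the estimate in this assay is -45%, expected to fall between -80% and -5%.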

Compound 4, a percentage reported as activity, at one concentration (the size of the read-out at that concentration, not a potency): -76%
Estimate against measurement, compound 4: 31 percentage points above; measured number inside the range.
By their numbers in this assay, from the lowest: compounds 3 and 4 (each within the scatter of the next); then compound 1; then compound 2.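

In this assay a directly attached ring proves unnecessary at this position: 3-(4-chlorophenyl)propyl, with its aromatic ring three carbons away from the ring nitrogen, in place of 3-chloro-4-fluorophenyl gives a number 2 percentage points higher from compound 3 to compound 4 (within the scatter). The same group in place of pyridin-4-yl gives a number 61 percentage points lower from compound 2 to compound 4 (beyond the scatter), and in place of 2-(trifluoromethyl)phenyl it gives a number 16 percentage points lower from compound 1 to compound 4 (beyond the scatter), so it matches 3-chloro-4-fluorophenyl within the scatter while standing apart from the other two groups. No measurement at hand accounts for two such differently built groups giving numbers within the scatter of each other.

Still open, on these data alone, is how much of this result belongs to the chain and how much to the ring at its end, which a shorter or longer chain, an unsubstituted phenyl at the end of the same chain, or an amine or carboxylic acid in place of that ring would begin to separate. Open too, as far as these compounds go, is whether compound 3 and compound 4 would stay together at other concentrations, since a reading at a single concentration gives no potency.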